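Chloro to Isopropyl on a Hydroxamate Deacetylase Series

This account rests on a few compounds, and the source may have more. Where it says the series, first, only, none or still open, it means among the compounds named here.

Measured so far:
Compound 1 `O=C(NO)c1ccc(NCc2nc(-c3ccc(Cl)cc3)nn2-c2ccccc2)cc1` — 67.2%
Compound 2 `Cc1cccc(-n2nc(-c3ccccc3)nc2CNc2ccc(C(=O)NO)cc2)c1` — 66%

Of the compounds shown here, two have been tested in an assay on Sf9 cells for inhibition of protein deacetylase HDAC6 (Homo sapiens), read by fluorescence, with a stated time of 40 min, tested at 100 nM; a lower number here means less inhibition, a higher number more inhibition at the concentration tested (going by the name of the read-out). Compound 1 gives 67.2% in this assay, and compound 2 gives 66%; compound 1 has the higher of the two numbers, but the gap to compound 2 lies within the scatter of repeated measurements, so the two read as equivalent. Among the measured compounds shown here, no two measured compounds differ in a single place, so no measured step is available.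

Compound 3 `CC(C)c1ccc(-c2nc(CNc3ccc(C(=O)NO)cc3)n(-c3ccccc3)n2)cc1` is the compound not yet measured. It differs from compound 1 by isopropyl in place of chloro on an aromatic carbon. The two measured compounds sit close together in this assay, compound 1 with 67.2% and compound 2 with 66%. The expectation is that this change produces no step beyond the scatter, or at most a small one in either direction. Compound 3 is therefore expected to give 63% in this assay, within a range of 45% to 78%, a step from compound 1 of a number 4.2 percentage points lower from compound 1 to compound 3 (within the scatter).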

Compound 3, a percentage reported as inhibition, at one concentration (the size of the read-out at that concentration, not a potency): 27.6%
Estimate against measurement, compound 3: 35.4 percentage points above; the whole stated range lies above it.
By their numbers in this assay, from the lowest: compound 3; then compounds 2 and 1 (each within the scatter of the next).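

Isopropyl in place of chloro on this aromatic carbon, para to a large group, gives a number 39.6 percentage points lower from compound 1 to compound 3 (beyond the scatter) in this assay and provides the first single-place comparison in the series. It shows that the read-out responds strongly to the group at this position, and that 4-chlorophenyl and 4-isopropylphenyl are not interchangeable here, although neither group adds a ring, a hydrogen-bond donor or acceptor, or a net charge. Nothing measured here explains the drop.

The compounds shown leave open whether the drop follows the larger count of heavy atoms or the identity of the incoming group, since one step cannot separate the two. As far as these compounds go, how a methyl, a methoxy or an amine on the same carbon would read in this assay also remains open.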